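Compound 1 with a new group on the amide nitrogen

The source may hold more compounds than are shown below. What is called first, only, known or untested is meant among the compounds shown, and "the series" means these compounds.

In a functional assay on HeLa cells (Homo sapiens) for cytotoxicity, read by MTT assay, with a stated time of 48 h (on this read-out lower numbers stand for stronger inhibition and higher numbers for weaker inhibition), three compounds have been measured so far:
compound 1 `COc1ccc(-c2cc(C(=O)Nc3nc4ccc(OC)cc4s3)nc3cc(-c4ccccc4)nn23)cc1`, 24500 nM;
compound 2 `COc1ccc2nc(NC(=O)c3cc(-c4ccc(OC)c(OC)c4)n4nc(-c5ccccc5)cc4n3)sc2c1`, 11000 nM;
compound 3 `COc1ccc2nc(NC(=O)c3cc(-c4cc(OC)c(OC)c(OC)c4)n4nc(-c5ccccc5)cc4n3)sc2c1`, 8700 nM.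

Compound 1 gives the highest number of the three. The steps away from it are a 2.2-fold lower number from compound 1 to compound 2 (0.35 log units; beyond the scatter) and a 2.8-fold lower number from compound 1 to compound 3 (0.45 log units; beyond the scatter); both add methoxy groups to the 4-methoxyphenyl group, and between the two enlarged compounds the step is a 1.3-fold lower number from compound 2 to compound 3 (0.10 log units; within the scatter). Compound 4 `COc1ccc(-c2cc(C(=O)Nc3nc4cc(C)c(C)cc4s3)nc3cc(-c4ccccc4)nn23)cc1` differs from compound 1 in another part of the molecule: 5,6-dimethyl-1,3-benzothiazol-2-yl in place of 6-methoxy-1,3-benzothiazol-2-yl on an amide-type nitrogen. For the measured compounds named here, no measured pair touches this group, so the measured steps give no direct guide. They show only that small additions elsewhere moved the number modestly, and nothing suggests a large move here. The expected step is therefore small: a 1.2-fold lower number from compound 1 to compound 4 (0.09 log units; within the scatter). Compound 4 is estimated at 20000 nM, with a range from 7000 nM to 60000 nM.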

Compound 4, half-maximal inhibitory concentration: 14100 nM
Compound 4: the middle estimate sits 1.4-fold (0.15 log units) above what was measured, within the range that was stated.
By their numbers in this assay, from the lowest: compounds 3, 2, 4 and 1 (each within the scatter of the next, the first and the last beyond it).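

For the compounds shown here, until now every compound carried the same 6-methoxy-1,3-benzothiazol-2-yl group on the amide nitrogen, so this is the first reading of what that group contributes in this assay. Replacing the methoxy with two methyl groups keeps the count of heavy atoms and removes the oxygen from this group, and the result is a 1.7-fold lower number from compound 1 to compound 4 (0.24 log units; within the scatter), so this particular swap does not clearly shift the number and the methoxy oxygen is not shown to matter here. No supporting data explain this outcome.

With only these two groups compared, the compounds shown leave open how far this position tolerates larger differences, such as a carboxylic acid, an amine or a longer alkyl chain on the 1,3-benzothiazol-2-yl group. They also leave open whether the 5,6-dimethyl group would behave the same way alongside the 3,4,5-trimethoxyphenyl group of compound 3.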